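Thiosemicarbazone series: removal of the iodo substituent

The source may hold more compounds than are shown below. What is called first, only, known or untested is meant among the compounds shown, and "the series" means these compounds.

Measured so far in a functional assay on T98G cells (Homo sapiens) for cytotoxicity, read by MTT assay, with a stated time of 48 h; on this read-out lower numbers stand for stronger inhibition and higher numbers for weaker inhibition:
compound 1 `C/C(=N/NC(=S)Nc1ccccc1I)c1ccccn1` gives 8.09 nM
compound 2 `C/C(=N\NC(=S)Nc1cccc(F)c1)c1ccccn1` gives 12 nM
compound 3 `CC(=NNC(=S)Nc1ccccc1I)c1ccccn1` gives 8.1 nM

Compound 1 holds the lowest number of the three, though its gaps to compound 3 and to compound 2 both lie within the scatter; the only single-point step measured, a 1.0-fold higher number from compound 1 to compound 3 (0.00 log units; within the scatter), concerns drawing alone, as shown by the fact that one of compounds 1 and 3 is drawn with a defined configuration and the other without, at the place where they differ.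

Compound 4 `C/C(=N/NC(=S)Nc1ccccc1)c1ccccn1` differs from compound 1 by hydrogen in place of iodo on an aromatic carbon. Going by the values given here, no measured step removes a halogen, so nothing bears directly on this change; compound 2, which carries fluoro on the same ring, sits close to compound 1. The step is therefore expected to be small, and compound 4 is estimated at 13 nM (range 5 nM to 35 nM), which corresponds to an expected step of a 1.6-fold higher number from compound 1 to compound 4 (0.21 log units; within the scatter) in this assay.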

Compound 4, half-maximal inhibitory concentration: 6.81 nM
Beside the measured number, compound 4's estimate is 1.9-fold (0.28 log units) above it; the range from low to high includes it.
By their numbers in this assay, from the lowest: compounds 4, 1, 3 and 2 (each within the scatter of the next).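

In this assay the iodo proves dispensable at this position: the step for hydrogen in its place is a 1.2-fold lower number from compound 1 to compound 4 (0.07 log units; within the scatter) and so stays small. Going by these compounds alone, the earlier compounds held no step removing a halogen, so this is the first direct reading on this aromatic carbon, and a number in this range does not depend on iodo being present. No available evidence bears on why this change leaves the number in this range.

Still open, from the compounds shown here alone, is whether an amine or a carboxylic acid on this carbon would keep the number in this range. Compounds 1 and 4 also leave open how a methoxy group or a longer chain would behave here.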